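Compound 4: a new side chain on a shared core

The source may report more compounds than this note shows. Statements on the series, on what has been measured and on what is new or still open speak of the compounds shown alone.

In a physicochemical assay for solubility, in phosphate buffer, measured as thermodynamic solubility, at pH 2 (on this read-out lower numbers stand for lower solubility and higher numbers for higher solubility), compound 1 (`NC1CCN(c2nc3c(c(Nc4ccc(C(F)(F)F)cc4)n2)CCN(c2ncccc2C(F)(F)F)CC3)C1`) gives > 215 ug/mL as a limit and not a number. Compound 2 (`CN(c1nc2c(c(Nc3ccc(C(F)(F)F)cc3)n1)CCN(c1ncccc1C(F)(F)F)CC2)C1CCCNC1`) gives > 241 ug/mL as a limit too. From the compounds shown here alone, compound 3 (`CN1CCCCC1CNc1nc2c(c(Nc3ccc(C(F)(F)F)cc3)n1)CCN(c1ncccc1C(F)(F)F)CC2`) gives > 277 ug/mL as a limit as well, so its true place on the scale stays open.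

Compound 4 (`CC(=O)NC1CCN(c2nc3c(c(Nc4ccc(C(F)(F)F)cc4)n2)CCN(c2ncccc2C(F)(F)F)CC3)C1`) has not yet been measured. It differs from compound 3 by carrying 3-acetamidopyrrolidin-1-yl in place of ((1-methylpiperidin-2-yl)methyl)amino on an aromatic carbon. The entering group has a double bond outside aromatic rings, which none of the groups measured so far has.

Three measured steps swap groups at this same place: there is a step that the two limits leave unreadable from compound 1 to compound 2 first, then a step that the two limits leave unreadable from compound 1 to compound 3 and also a step that the two limits leave unreadable from compound 2 to compound 3 in turn. All three join limits, so they offer no size to carry over. The direction expected here is downward, as a judgement with little support, and the estimate is an at least 6.9-fold lower number from compound 3 to compound 4 (0.84 log units; beyond the scatter) with wide uncertainty.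

Compound 4 is expected near 40 ug/mL in this assay with an estimated range from 5 ug/mL to 250 ug/mL for this measurement.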

Compound 4, solubility: 202 ug/mL
Compound 4: middle estimate off by 5.1-fold (0.70 log units), on the low side, and the stated range covers the measured number.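

In this assay, among these compounds, compound 4 gives 202 ug/mL, the first reading at this position that is a number and not a limit. Placing acetyl on the amine nitrogen of the side chain of compound 1 is the smallest change here, and it gives an at least 1.0-fold lower number from compound 1 to compound 4 (0.02 log units; that floor lies within the scatter). The two larger swaps of the whole side chain give an at least 1.1-fold lower number from compound 2 to compound 4 (0.07 log units; that floor lies within the scatter) and an at least 1.3-fold lower number from compound 3 to compound 4 (0.13 log units; that floor lies within the scatter), so each of these steps has a floor but no measured size.

From the compounds shown here alone, how far compound 4 truly lies from compound 3 stays open because the starting value is only a limit: the limit of > 277 ug/mL in this assay, at which 1 of the 4 values shown sits. Going by these compounds, whether a methanesulfonyl group or a longer acyl chain in place of acetyl on that amine nitrogen would read like compound 4 also stays open.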